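A few compounds are considered here, and "the series" means these few. Any claim that something is new, unique, unknown or untested is made for them only; others in the source may bear on it.

Of the compounds shown here, three built on one shared core have been tested in a functional assay on A549 cells (Homo sapiens) for cytotoxicity, read by MTT assay, with a stated time of 72 h; on this read-out higher numbers stand for weaker inhibition and lower numbers for stronger inhibition. Compound 1 `COc1cccc(/C=C2\CCC/C(=C\c3ccc(Cl)cc3)C2=O)c1OC` gives in this assay the value > 20000 nM, which is a limit of the assay rather than a number. Compound 2 `COc1ccc(/C=C2\CCC/C(=C\c3cccc(OC)c3OC)C2=O)cc1` likewise gives in this assay the limit > 20000 nM. Compound 3 `COc1ccc(/C=C2\CCC/C(=C\c3ccccc3Br)C2=O)cc1OC` gives in this assay the limit > 20000 nM. Among the measured compounds shown here, the single one-place step that the two limits leave unreadable from compound 1 to compound 2, methoxy in place of chloro on an aromatic carbon, adds no readable size, since both of its ends are limits. Compound 3 thus stands exactly where every measured compound stands, at the limit of > 20000 nM in this assay, at which 3 of the 3 values shown sit. Compound 4 `COc1ccc(/C=C2\CCC/C(=C\c3cc(Cl)cc(Cl)c3)C2=O)cc1OC` differs from compound 3 by 3,5-dichlorophenyl in place of 2-bromophenyl on a double-bonded chain carbon bound to a double-bonded ring carbon. For the measured compounds named here, no measured step covers this change, and the one step that exists cannot be read, so nothing here anchors a direction or a size for it. Compound 4 is expected to give another limit, an estimated step that the limit leaves unreadable from compound 3 to compound 4. The estimate for compound 4 in this assay is 30000 nM, with a range from 8000 nM to 120000 nM.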

Compound 4, half-maximal inhibitory concentration: 5500 nM
Beside the measured number, compound 4's estimate is 5.5-fold (0.74 log units) above it; the whole stated range lies above it.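

In this assay, among the compounds shown here, 3,5-dichlorophenyl in place of 2-bromophenyl on a double-bonded chain carbon bound to a double-bonded ring carbon gives an at least 3.6-fold lower number from compound 3 to compound 4 (0.56 log units; beyond the scatter), which is the first readable step here, as the earlier step joins two limits and cannot be read. Compound 3 sits at a limit of the assay and not at a number, so this step gives only the smallest size the change can have, and the true size may be larger. This position can therefore move the read-out towards stronger inhibition, and compound 4 is the only compound shown to leave the limit: the limit of > 20000 nM in this assay, at which 3 of the 4 values shown sit.

The change replaces bromine with chlorine and alters the number of halogens in one move, so the compounds shown cannot say which of these matters. From the compounds shown here alone, whether an amine or a carboxylic acid on this phenyl ring would also leave the limit remains open.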